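The compounds below may be only part of what the source reports. "The series", "measured", "known", "first", "only" and "open" are said of these compounds alone.

Measured compounds in a functional assay on CCRF-CEM cells (Homo sapiens) for cytotoxicity, read by MTT assay, with a stated time of 72 h; on this read-out lower numbers stand for higher toxicity in this test and higher numbers for lower toxicity in this test:

Compound 1 `CCCCOC(=O)Nc1ccc([Se]C#N)cc1` gives 63500 nM.
Compound 2 `CC(C)COC(=O)Nc1ccc([Se]C#N)cc1` gives 68700 nM.
Compound 3 `N#C[Se]c1ccc(NC(=O)Oc2ccc(Cl)cc2)cc1` gives 71800 nM.

Compound 3 has the highest of the three numbers in this assay, but its gaps to compound 2 and to compound 1 are both within the scatter, so the three carbamates cannot be told apart on these data. Within the data shown here, the only one-place step measured is a 1.1-fold higher number from compound 1 to compound 2 (0.03 log units; within the scatter), a change on the alkyl chain of the carbamate that leaves the number essentially unchanged.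

Compound 4 `N#C[Se]c1ccc(NC(=O)Oc2ccccc2)cc1` is not yet measured. It differs from compound 3 by hydrogen in place of chloro on an aromatic carbon. Among the measured compounds shown here, no measured step touches the aryl part of the carbamate, so nothing speaks directly to this change; the one step that exists, from compound 1 to compound 2, is on a different part of the molecule and is within the scatter. With the three measured numbers sitting so close together, no step beyond the scatter is expected here either, and the step of a 1.0-fold lower number from compound 3 to compound 4 (0.01 log units; within the scatter) is estimated to stay within the scatter. Compound 4 is therefore expected to give about 70000 nM in this assay, with a range from 35000 nM to 140000 nM.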

Compound 4, concentration lethal to 50% of the cells: 73200 nM
For compound 4 the middle estimate is 1.0-fold (0.02 log units) below the measured one, within the range that was stated.
By their numbers in this assay, from the lowest: compounds 1, 2, 3 and 4 (each within the scatter of the next).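

In this assay, among these compounds, the aromatic carbon carrying chloro is probed for the first time: hydrogen in its place gives a 1.0-fold higher number from compound 3 to compound 4 (0.01 log units; within the scatter) and so, at this place para to a large group, the two cannot be told apart. The group on the carbamate oxygen can now be read across ring and chain as well, with phenyl in place of isobutyl giving a 1.1-fold higher number from compound 2 to compound 4 (0.03 log units; within the scatter) and phenyl in place of butyl giving a 1.2-fold higher number from compound 1 to compound 4 (0.06 log units; within the scatter) and thus no separation between the aryl and alkyl carbamates shown. No measurement is available that would explain why these numbers sit so close together.

From the compounds shown here alone, whether an amine, a carboxylic acid or a methoxy group on this aromatic carbon would move the number beyond the scatter remains open. Also open, going by these compounds, is whether any change to the shared core, away from the carbamate, would shift the number at all.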